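A few compounds are considered here, and "the series" means these few. Any claim that something is new, unique, unknown or untested is made for them only; others in the source may bear on it.

Compound 1 (`COC(=O)c1cc(-c2cccc(NC(=O)c3ccc(/C=C/C(=O)c4cc(OC)c(OC)c(OC)c4)cc3)c2)on1`) gives > 50 ug/mL in an ADME assay on Vero cells (Chlorocebus sabaeus) for cytotoxicity, read by MTT assay, with a stated time of 72 h; on this read-out lower numbers stand for higher toxicity in this test and higher numbers for lower toxicity in this test.
Compound 2 (`COC(=O)c1cc(-c2cccc(NC(=O)c3ccc(/C=C/C(=O)c4cccc(C(F)(F)F)c4)cc3)c2)on1`) gives > 20 ug/mL in this assay.
Compound 3 (`COC(=O)c1cc(-c2cccc(NC(=O)c3ccc(/C=C/C(=O)c4ccc(OC)cc4)cc3)c2)on1`) gives > 10 ug/mL in this assay.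

Each of these three values is a limit of this assay and not a measured number. Compound 3 stands at the limit of > 10 ug/mL in this assay, at which 1 of the 3 values shown sits. Compound 2 stands at the limit of > 20 ug/mL in this assay, at which 1 of the 3 values shown sits. Compound 1 stands at the limit of > 50 ug/mL in this assay, at which 1 of the 3 values shown sits. Because all three are limits, the steps between them cannot be sized: a step that the two limits leave unreadable from compound 1 to compound 2, a step that the two limits leave unreadable from compound 1 to compound 3 and a step that the two limits leave unreadable from compound 2 to compound 3 all remain unreadable, so nothing here shows whether changing the group on the carbonyl carbon moves the read-out at all.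

Compound 4 (`COC(=O)c1cc(-c2cccc(NC(=O)c3ccc(/C=C/C(=O)c4ccc(Cl)cc4)cc3)c2)on1`) differs from compound 3 by chloro in place of methoxy on an aromatic carbon. Going by the values given here, no measured step bears readably on this change, so no direction beyond the scatter can be expected; the estimated step is a step that the limit leaves unreadable from compound 3 to compound 4. Compound 4 is therefore expected to give about 30 ug/mL in this assay, within a range from 10 ug/mL to 100 ug/mL, and most likely to be reported again only as a limit.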

Compound 4, half-maximal cytotoxic concentration: > 50 ug/mL
Compound 4: no number, only a limit; the forecaster's own chance of this, stated with the estimate: 70%; middle value at least 1.6-fold (0.22 log units) from the limit.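

The result for compound 4 is again a limit and not a number, so its steps to compound 1, compound 2 and compound 3 cannot be read. The compounds shown leave open whether changing the group on the carbonyl carbon moves the read-out in this assay at all.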